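The source may hold more compounds than are shown below. What is called first, only, known or untested is meant among the compounds shown, and "the series" means these compounds.

Compound 1 `O=C(O)[C@H]1CC[C@](F)(C(=O)N2CC[C@](c3ccc(C(F)(C(F)(F)F)C(F)(F)F)cc3)(S(=O)(=O)c3ccc(F)cc3)C2)CC1` has no result in an ADME assay on microsomes from liver (Mus musculus) for metabolic stability, with a stated time of 10 min; on this read-out lower numbers stand for a less stable compound and higher numbers for a more stable compound; the entry for compound 1 in this assay reads "not determined" (no result reported), so no number was reported for it. Compound 2 `O=C(N1CC[C@](c2ccc(C(F)(C(F)(F)F)C(F)(F)F)cc2)(S(=O)(=O)c2ccc(F)cc2)C1)C1(F)CCS(=O)(=O)CC1` shares the core of compound 1; in this assay compound 2 gives 90%. Compound 3 `O=C(N1CC[C@](c2ccc(C(F)(C(F)(F)F)C(F)(F)F)cc2)(S(=O)(=O)c2ccc(F)cc2)C1)C1(O)CCS(=O)(=O)CC1` has not yet been measured. Going from compound 1 to compound 3, the change is 4-hydroxy-1,1-dioxothian-4-yl in place of 4-carboxy-1-fluorocyclohexyl on a carbonyl carbon. Among the compounds with values here, with no number for compound 1, no step can be sized from it in either direction, and the only guide is that compound 2 gives 90% in this assay. On that basis compound 3 is expected to come out near 85%, estimated to fall between 65% and 98% in this assay.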

Compound 3, percent of the compound remaining: 90%
Estimate against measurement, compound 3: 5 percentage points below, and the stated range covers the measured number.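

Within the data shown here, this is the first pair of compounds that differ in one place, so a step at this position can now be read: with hydroxy in place of fluoro on a saturated ring carbon, this assay shows no change at the digits printed from compound 2 to compound 3 (within the scatter) for this pair. In this one pair, the read-out does not separate the two groups, while steps from compound 1 cannot be read. No measured evidence here explains this result. Still open, as far as these compounds go, is how an amine or a methoxy group on the same ring carbon would compare in this assay with hydroxy and fluoro.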